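The source may hold more compounds than are shown below. What is called first, only, known or untested is meant among the compounds shown, and "the series" means these compounds.

Measured compounds:
compound 1, `CC1(C)CO[C@@H]1CN([C@H](CCC(F)(F)F)C(N)=O)S(=O)(=O)c1ccc(Cl)cc1` — 22.3 10^-6 cm/s
compound 2, `NC(=O)[C@@H](CCC(F)(F)F)N(C[C@@H]1CCCOC1)S(=O)(=O)c1ccc(Cl)cc1` — 18.4 10^-6 cm/s

Both numbers come from an ADME assay on MDCKII-LE cells (Canis lupus familiaris) for permeability, read by transwell migration, in the apical to basolateral direction; a higher number here means that the compound crosses the layer faster, a lower number that the compound crosses the layer more slowly. In this assay, among the compounds with values here, compound 1 gives 22.3 10^-6 cm/s, and compound 2 gives 18.4 10^-6 cm/s; the single measured step, a 1.2-fold lower number from compound 1 to compound 2 (0.08 log units; within the scatter), is within the scatter, so the two compounds cannot be told apart on permeability. Compound 2 therefore stands as the lowest of the two numbers only by the bare figure, with compound 1 within the scatter of it.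

Compound 3, `NC(=O)[C@@H](CCC(F)(F)F)N(C[C@H]1CCO1)S(=O)(=O)c1ccc(Cl)cc1`, has not yet been measured in this assay. It differs from compound 2 in one place: oxetan-2-yl in place of oxan-3-yl on a saturated chain carbon bound to a sulfonamide nitrogen. Within the data shown here, the one step that bears on this change is the exchange of one saturated oxygen ring for another at the same place, from compound 1 to compound 2, and that step was within the scatter. On that basis no step beyond the scatter is expected for compound 3, and a 1.2-fold lower number from compound 2 to compound 3 (0.06 log units; within the scatter) is the expected size. Compound 3 is estimated at 16 10^-6 cm/s, with a range from 9 10^-6 cm/s to 28 10^-6 cm/s.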

Compound 3, apparent permeability: 28.7 10^-6 cm/s
Compound 3: middle estimate off by 1.8-fold (0.25 log units), on the low side, and the stated range ends below it.
By their numbers in this assay, from the lowest: compounds 2, 1 and 3 (each within the scatter of the next).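

At the saturated chain carbon bound to a sulfonamide nitrogen, the four-membered oxetan-2-yl now stands with the six-membered oxan-3-yl and with 3,3-dimethyloxetan-2-yl, and in this assay the exchanges read as a 1.6-fold higher number from compound 2 to compound 3 (0.19 log units; within the scatter) and as a 1.3-fold higher number from compound 1 to compound 3 (0.11 log units; within the scatter). The earlier pair had compared only oxan-3-yl with 3,3-dimethyloxetan-2-yl, whereas these steps add the change from the six-membered ring to the four-membered ring and the change from the dimethylated oxetane to the plain one, and neither lies beyond the scatter, so the three compounds cannot be told apart on this read-out. Nothing available here bears on the reason for these numbers.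

All three groups are saturated rings holding one oxygen, so the compounds shown leave open whether the same flat picture would hold for a ring carrying an amine, a carboxylic acid or an open-chain ether at this place. Within the data shown here, they also leave open whether the stereocentre in each ring matters, since no two compounds here differ only in its configuration.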